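Styryl sulfone series: third methoxy on the styryl ring

The compounds below may be only part of what the source reports. "The series", "measured", "known", "first", "only" and "open" are said of these compounds alone.

Measured compounds, read in a functional assay on DU-145 cells (Homo sapiens) for antiproliferative activity, read by trypan blue exclusion; a higher number here means a weaker inhibitor, a lower number a stronger inhibitor:
compound 1, `COc1ccc(CS(=O)(=O)/C=C/c2ccc(OC)c(OC)c2)cc1`, > 20000 nM (a limit, not a number)
compound 2, `COc1ccc(CS(=O)(=O)/C=C/c2ccc(OC)cc2OC)cc1`, > 20000 nM (a limit, not a number)
compound 3, `COc1ccc(CS(=O)(=O)/C=C/c2cc(OC)ccc2OC)cc1`, > 20000 nM (a limit, not a number)

Within the data shown here, compound 3 stands only at the limit of this assay; all values so far sit there, see (the limit of > 20000 nM in this assay, at which 3 of the 3 values shown sit). Among the measured compounds shown here, no step between measured compounds is therefore resolved, and nothing separates one methoxy pattern from another.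

Compound 4, `COc1ccc(CS(=O)(=O)/C=C/c2cc(OC)c(OC)cc2OC)cc1`, differs from compound 3 by methoxy in place of hydrogen on an aromatic carbon. For the measured compounds named here, with no resolved step to rest on, no step beyond the scatter is expected in this assay, though a limit value would leave any gain hidden. Compound 4 is estimated at 20000 nM with a range of 4000 nM to 60000 nM. The expected step is a number no higher from compound 3 to compound 4 (the limit leaves the size open).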

Compound 4, half-maximal inhibitory concentration: > 20000 nM
Compound 4 ended at the assay's limit; the forecaster's own chance of this, stated with the estimate: 60%; the middle value lies on the limit itself.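

In this assay compound 4 gives > 20000 nM, a limit and not a number. The steps from compound 1, compound 2 and compound 3 to compound 4 cannot be read: the limit of > 20000 nM in this assay, at which 4 of the 4 values shown sit.

As far as these compounds go, whether any of these methoxy patterns differs from another in this assay stays open.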